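The compounds below may be only part of what the source reports. "The series", "measured", "known", "first", "only" and "open" are said of these compounds alone.

Compound 1 `CCOc1ccc2c(=O)c(-c3ccc(O)cc3)coc2c1` gives 100% in a functional assay on mitochondria (Cricetulus griseus) for inhibition of Monoamine oxidase (Homo sapiens), tested at 9 uM; a higher number here means a stronger effect of the compound at the concentration tested, a lower number a weaker effect.
Compound 2 `O=c1c(-c2ccc(O)cc2)coc2cc(OCCCCCCBr)ccc12` gives 95.7% in this assay.
Compound 3 `O=C(O)CCCCCCCCCOc1ccc2c(=O)c(-c3ccc(O)cc3)coc2c1` gives 95% in this assay.

Compound 2 stands second highest of the three numbers; its nearest neighbour is compound 3, its furthest compound 1, and both gaps are within the scatter. The change a number 4.3 percentage points lower from compound 1 to compound 2 (within the scatter) and the change a number 5 percentage points lower from compound 1 to compound 3 (within the scatter) both lie within the scatter, so the three measured compounds are indistinguishable in this assay.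

Compound 4 `O=C(O)CCCCCCOc1ccc2c(=O)c(-c3ccc(O)cc3)coc2c1` has not yet been measured. It differs from compound 2 by carboxy in place of bromo on a saturated chain carbon, six bonds along the chain from an oxygen on an aromatic ring. The step that bears most directly on this is a number 0.7 percentage points lower from compound 2 to compound 3 (within the scatter), in which a carboxy-bearing chain also takes the place of the bromo; it was within the scatter. With all three measured steps within the scatter and compound 2 already near the top of the range, no step beyond the scatter is expected in this assay, and the estimated step is a number 0.7 percentage points lower from compound 2 to compound 4 (within the scatter). Compound 4 is therefore expected to give about 95%, likely between 85% and 100%.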

Compound 4, a percentage reported as inhibition, at one concentration (the size of the read-out at that concentration, not a potency): 94.6%
Compound 4: middle estimate off by 0.4 percentage points, on the high side; the measured number falls inside the stated range.
By their numbers in this assay, from the lowest: compounds 4, 3, 2 and 1 (each within the scatter of the next).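

In this assay, carboxy in place of bromo on a saturated chain carbon, six bonds along the chain from an oxygen on an aromatic ring, produces no readable difference (a number 1.1 percentage points lower from compound 2 to compound 4 (within the scatter)), so compound 2 and compound 4 cannot be told apart despite the exchange of a single bromine for a group of 3 heavy atoms with a hydrogen-bond donor. Carboxy in place of 3-carboxypropyl at that same carbon also shows no readable difference (a number 0.4 percentage points lower from compound 3 to compound 4 (within the scatter)), and neither does the whole 4-carboxybutyl addition (a number 5.4 percentage points lower from compound 1 to compound 4 (within the scatter)), so neither this chain length nor the carboxy group separates these compounds. Nothing measured here offers an explanation for this result.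

An amine or an amide in place of the carboxy, or a longer chain, might or might not separate from these compounds. From the compounds shown here alone, whether the four compounds would differ at a lower concentration also stays open.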